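Expected clearance of compound 4 from compound 2

A few compounds are considered here, and "the series" means these few. Any claim that something is new, unique, unknown or untested is made for them only; others in the source may bear on it.

Values so far in an in vitro ADME assay on microsomes from liver (Homo sapiens) for pharmacokinetics, read by LC-MS, with a stated time of 10 min, tested at 1 uM (on this read-out higher numbers stand for fast clearance and lower numbers for slow clearance), for the three measured compounds
- compound 1 `Cc1ccc(NC(=O)[C@H]2CN(C)C[C@@H]2c2ccc(/C=C/C(=O)Nc3ccccc3N)cc2)cc1` gives 15 mL/min/kg
- compound 2 `COc1ccc(NC(=O)[C@H]2CN(C)C[C@@H]2c2ccc(/C=C/C(=O)Nc3ccccc3N)cc2)cc1` gives 14 mL/min/kg
- compound 3 `CC(C)c1ccc(NC(=O)[C@H]2CN(C)C[C@@H]2c2ccc(/C=C/C(=O)Nc3ccccc3N)cc2)cc1` gives 10 mL/min/kg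

Compound 2 cannot be separated from compound 1 or compound 3 on these numbers. Its two steps are a 1.1-fold lower number from compound 1 to compound 2 (0.03 log units; within the scatter) and a 1.4-fold lower number from compound 2 to compound 3 (0.15 log units; within the scatter) and neither resolves it from the others. The remaining pair shows a 1.5-fold lower number from compound 1 to compound 3 (0.18 log units; within the scatter) and is equally unresolved.

The step under consideration leads to compound 4 `CN1C[C@H](C(=O)Nc2cccc(Cl)c2)[C@@H](c2ccc(/C=C/C(=O)Nc3ccccc3N)cc2)C1` and is 3-chlorophenyl in place of 4-methoxyphenyl on an amide-type nitrogen in the form of 3-chlorophenyl in place of 4-methoxyphenyl on an amide-type nitrogen. The measured steps bear on this only indirectly, since they exchange methyl, methoxy and isopropyl on an aromatic carbon. For the measured compounds named here, no measured compound carries 3-chlorophenyl, so the data hold no direct reading of this exchange. Taking a 1.4-fold lower number from compound 2 to compound 3 (0.15 log units; within the scatter) as the reference, the expected change is no change at the digits printed from compound 2 to compound 4 (within the scatter) in this assay with no direction favoured and nothing beyond the scatter anticipated. Compound 4 is estimated at 14 mL/min/kg with an expected range from 8 mL/min/kg to 25 mL/min/kg on this basis.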

Compound 4, clearance: 7 mL/min/kg
For compound 4 the middle estimate is 2.0-fold (0.30 log units) above the measured one; measured number outside the range, below it.
By their numbers in this assay, from the lowest: compounds 4, 3, 2 and 1 (each within the scatter of the next, the first and the last beyond it).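

In this assay the position on the amide-type nitrogen gives its first resolved pair with 3-chlorophenyl in place of 4-methylphenyl, where a 2.1-fold lower number from compound 1 to compound 4 (0.33 log units; beyond the scatter) is a modest step and the only one in the series printed beyond the scatter. Against the other two aryl groups the same position stays unresolved: a 2.0-fold lower number from compound 2 to compound 4 (0.30 log units; within the scatter) and a 1.4-fold lower number from compound 3 to compound 4 (0.15 log units; within the scatter) both lie within the scatter, so compound 4 separates from compound 1 alone, and the exchanges of methyl, methoxy and isopropyl had separated no pair at all. No measurement at hand gives a reason for the step from compound 1 to compound 4.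

Since 3-chlorophenyl differs from 4-methylphenyl in both the substituent and its place on the ring, the compounds shown cannot say which of the two carries the step, and a 4-chlorophenyl or a 3-methylphenyl amide would divide them. Also open, from the compounds shown here alone, is how clearance responds on this nitrogen to an unsubstituted phenyl, or to an aryl group bearing a dimethylamino group or a carboxylic acid.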